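Compound 1 to compound 4: cyclohexyl for cyclopropylmethyl

A few compounds are considered here, and "the series" means these few. Any claim that something is new, unique, unknown or untested is made for them only; others in the source may bear on it.

Measured so far in an ADME assay on liver for metabolic stability, with Liver microsome (Homo sapiens) as the target, read by LC-MS, using microsomes; a lower number here means slower removal, a higher number faster removal of the compound:
- compound 1 `O=C(NCc1cc(Cl)ccc1-n1cnnn1)[C@@H]1C[C@@H]2C[C@@H]2N1C(=O)[C@H](O)CC1CC1`: < 12 mL.min-1.g-1 (a limit)
- compound 2 `CC1(C[C@@H](O)C(=O)N2N=CC[C@H]2C(=O)NCc2cc(Cl)ccc2-n2cnnn2)CC1`: < 12 mL.min-1.g-1 (a limit)
- compound 3 `O=C([C@H](O)c1ccccc1)N1CC[C@@H]2C[C@@]21C(=O)NCc1cc(Cl)ccc1-n1cnnn1`: 43 mL.min-1.g-1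

Compound 1 has no exact number and stands at the limit of < 12 mL.min-1.g-1 in this assay, at which 2 of the 3 values shown sit. Any step that starts from compound 1 therefore starts from a limit and not from a number.

Compound 4 `O=C(NCc1cc(Cl)ccc1-n1cnnn1)[C@@H]1C[C@@H]2C[C@@H]2N1C(=O)[C@H](O)C1CCCCC1` keeps the core of compound 1 and differs in one place: cyclohexyl in place of cyclopropylmethyl on a saturated chain carbon bound to a carbonyl carbon and an oxygen on a saturated carbon. The count of that difference is cyclohexyl in place of cyclopropylmethyl on a saturated chain carbon bound to a carbonyl carbon and an oxygen on a saturated carbon.

Among the measured compounds shown here, no measured pair isolates this change, so the expectation is only loosely anchored. For the measured compounds named here, it leans on compound 3 at 43 mL.min-1.g-1, the one measured compound that gives a number rather than a limit. A moderate move towards faster removal in this assay is expected, and the estimated step is an at least 2.0-fold higher number from compound 1 to compound 4 (0.31 log units; beyond the scatter). A reading that is again only a limit remains possible for compound 4. For compound 4 the estimate is 25 mL.min-1.g-1, with an expected range of 12 mL.min-1.g-1 to 60 mL.min-1.g-1.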

Compound 4, intrinsic clearance in microsomes: 150 mL.min-1.g-1
Compound 4: the middle estimate sits 6.0-fold (0.78 log units) below what was measured; the measured number lies above the stated range.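

In this assay, among the compounds shown here, the saturated chain carbon bound to a carbonyl carbon and an oxygen on a saturated carbon is the first place where a single change can be read, and cyclohexyl in place of cyclopropylmethyl gives an at least 12-fold higher number from compound 1 to compound 4 (1.09 log units; beyond the scatter). On the core of compound 1, this place is therefore far from indifferent: one change of group, with everything else held, takes the read-out from the floor of the assay to a number well clear of it. The value of compound 1 is a limit and not a number, so the step gives a minimum and not a size: the limit of < 12 mL.min-1.g-1 in this assay, at which 2 of the 4 values shown sit.

The change replaces a three-membered ring carried on a methylene link with a six-membered ring and no link, so the compounds shown leave open whether ring size, the link or the added carbon count accounts for the step. Cyclohexylmethyl, cyclopentyl or a tetrahydropyranyl ring at this same place would begin to separate these readings, and the same swap on another core would show whether the step carries over beyond the core of compound 1.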